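A few compounds are considered here, and "the series" means these few. Any claim that something is new, unique, unknown or untested is made for them only; others in the source may bear on it.

In a functional assay on KB 3-1 cells (Homo sapiens) for antiproliferative activity, read by WST assay, with a stated time of 5 days (on this read-out higher numbers stand for weaker inhibition and lower numbers for stronger inhibition), compound 2 (`COc1cc(O)c2c(c1O)C/C(C)=C\CC[C@@]1(C)O[C@@H]1C2=O`) gives 10000 nM, within the usual scatter of compound 1 (`COc1cc(O)c2c(c1O)C[C@]1(C)O[C@@H]1CC[C@@]1(C)O[C@@H]1C2=O`) at 9000 nM. Within the data shown here, compound 3 (`COc1cc(O)c2c(c1O)[C@@H](O)/C(C)=C\CC[C@@]1(C)O[C@@H]1C2=O`) gives 4100 nM, the lowest number so far. Compound 4 (`COc1cc(O)c2c(c1O)C/C(CO)=C\CC[C@@]1(C)O[C@@H]1C2=O`) differs from compound 2 by hydroxy in place of hydrogen on a saturated chain carbon bound to a double-bonded ring carbon, on a saturated chain carbon bound to a double-bonded ring carbon, so methyl becomes hydroxymethyl. Among the measured compounds shown here, one measured step bears on this, also hydroxy in place of hydrogen but on a saturated ring carbon: a 2.4-fold lower number from compound 2 to compound 3 (0.39 log units; beyond the scatter). Since the site differs, that modest step is only a loose guide, and a similar or smaller drop is expected. The expected change is a 1.5-fold lower number from compound 2 to compound 4 (0.19 log units; within the scatter). Compound 4 is estimated at 6500 nM, with an expected range of 2800 nM to 14000 nM.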

Compound 4, half-maximal inhibitory concentration: 59000 nM
Estimate against measurement, compound 4: 9.1-fold (0.96 log units) below; the measured number lies above the stated range.
By their numbers in this assay, from the lowest: compound 3; then compounds 1 and 2 (each within the scatter of the next); then compound 4.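

In this assay, methyl to hydroxymethyl on this saturated chain carbon bound to a double-bonded ring carbon gives a 5.9-fold higher number from compound 2 to compound 4 (0.77 log units; beyond the scatter) and so weakens inhibition, whereas hydroxy on a saturated ring carbon gave a 2.4-fold lower number from compound 2 to compound 3 (0.39 log units; beyond the scatter). Among these compounds, then, adding hydroxy has no single direction: the outcome differs between the two sites. Nothing measured here explains the rise. Still open, from the compounds shown here alone, is whether the rise follows the free hydroxy itself or any group other than methyl on this carbon; a methoxymethyl or an ethyl group there would help to separate the two.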